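The source may report more compounds than this note shows. Statements on the series, on what has been measured and on what is new or still open speak of the compounds shown alone.

In a functional assay on MCF7 cells (Homo sapiens) for inhibition, read by MTT assay, with a stated time of 72 h (on this read-out higher numbers stand for weaker inhibition and lower numbers for stronger inhibition), compound 1 `CN(C(=O)NC(=O)c1ccc(Cl)c(Cl)c1)c1nc(C(F)(F)F)c(C(=O)N/N=C/c2ccc([N+](=O)[O-])cc2)s1` gives 6.74 ug/mL, and compound 2 `CN(C(=O)NC(=O)c1ccc(F)c(F)c1)c1nc(C(F)(F)F)c(C(=O)N/N=C/c2cccc(C(F)(F)F)c2)s1` gives 4.15 ug/mL. Compound 3 `CNc1nc(C)c(C(=O)N/N=C/c2cccc(C(F)(F)F)c2)s1` returns no number in this assay, only a limit of > 100 ug/mL. Within the data shown here, compound 3 therefore stands at the weak end of the three values shown, at the limit of > 100 ug/mL in this assay, at which 1 of the 3 values shown sits, while compounds 1 and 2 lie far inside the measurable range; compound 3 differs from both of them at several places, so no single structural step connects it to either. Compound 4 `CNc1nc(C)c(C(=O)N/N=C/c2cc(C(F)(F)F)cc(C(F)(F)F)c2)s1` differs from compound 3 by trifluoromethyl in place of hydrogen on an aromatic carbon. Among the measured compounds shown here, no pair of measured compounds differing in one place is available to calibrate what such a change does in this assay. Since compound 3 is already at the limit, the account expects the step to be a number no higher from compound 3 to compound 4 (the limit leaves the size open), that is, nothing beyond the scatter. Compound 4 is thus estimated at 100 ug/mL, within a range from 30 ug/mL to 300 ug/mL, and most likely again reported only as a limit.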

Compound 4, half-maximal inhibitory concentration: > 100 ug/mL
Compound 4 was reported as a limit (the forecaster's own chance of this, stated with the estimate: 70%); the middle value sits exactly at the limit.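

Compound 3 and compound 4 both stand only at a limit, so no step can be read between them: the limit of > 100 ug/mL in this assay, at which 2 of the 4 values shown sit.

The compounds shown leave open what trifluoromethyl in place of hydrogen on an aromatic carbon does to inhibition, in either direction and of any size.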